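Halogen swap on the anilino ring: fluoro to chloro

This account rests on a few compounds, and the source may have more. Where it says the series, first, only, none or still open, it means among the compounds named here.

Compound 1 `O=C(/C=C\Nc1ccc(F)cc1)c1nc(-c2ccc(C(F)(F)F)cc2)n2ccccc12` in a functional assay on MDA-MB-231 cells (Homo sapiens) for cytotoxicity, read by MTT assay, with a stated time of 48 h (on this read-out higher numbers stand for weaker inhibition and lower numbers for stronger inhibition), gives > 30000 nM, which is a limit of the assay and not a number. Compound 2 `Cc1cc2cc(N/C=C\C(=O)c3nc(-c4ccc(F)cc4)n4ccccc34)ccc2[nH]1` in this assay likewise gives > 30000 nM, also a limit. Both values shown therefore sit at the limit of > 30000 nM in this assay, at which 2 of the 2 values shown sit, and compound 1 cannot be placed against any measured number. Compound 3 `O=C(/C=C\Nc1ccc(Cl)cc1)c1nc(-c2ccc(C(F)(F)F)cc2)n2ccccc12` is not yet measured; it carries chloro in place of fluoro on an aromatic carbon. Among the measured compounds shown here, no step between measured compounds is known, and no shift beyond the scatter is expected in either direction. Compound 3 is expected to give 30000 nM (range 10000 nM to 90000 nM). The estimated step of a number no higher from compound 1 to compound 3 (the limit leaves the size open) is expected to stay within the scatter.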

Compound 3, half-maximal inhibitory concentration: 3840 nM
Estimate against measurement, compound 3: 7.8-fold (0.89 log units) above, outside the stated range (below it).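

In this assay, among the compounds shown here, 4-fluorophenyl to 4-chlorophenyl gives an at least 7.8-fold lower number from compound 1 to compound 3 (0.89 log units; beyond the scatter), and compound 3 holds the only value shown that is not a limit. For the compounds shown here, this position, on an aromatic carbon para to a large group, therefore responds to a single halogen change, which the earlier compounds could not show. Compound 1 stands at a limit, so the size of the step stays open: the limit of > 30000 nM in this assay, at which 2 of the 3 values shown sit.

On these data alone, whether bromo, methyl or an amine at this position would match chloro remains open. So does whether chloro has the same effect on a different core substituent.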